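Swapping acetamido for methoxy where every value is a limit

The source may hold more compounds than are shown below. What is called first, only, known or untested is meant among the compounds shown, and "the series" means these compounds.

Of the compounds shown here, three have been tested in an ADME assay on L02 cells (Homo sapiens) for antiproliferative activity, read by MTT assay, with a stated time of 48 h; on this read-out lower numbers stand for stronger inhibition and higher numbers for weaker inhibition. Compound 1 `COc1ccc(-n2nncc2CN2C(=O)C3(C(C#N)=C(N)Oc4c3c3nc5ccccc5nc3c3ccccc43)c3ccccc32)cc1` carries a methoxy group on a six-membered aromatic ring of carbon only. In this assay compound 1 reaches only the assay limit, > 50000 nM. Compound 2 `CC(=O)Nc1ccc(-n2nncc2CN2C(=O)C3(C(C#N)=C(N)Oc4c3c3nc5ccccc5nc3c3ccccc43)c3ccccc32)cc1` shares the core of compound 1 but carries an acetamido group instead. In this assay compound 2 likewise stops at the assay limit, > 50000 nM. The difference between compound 2 and compound 1 is methoxy in place of acetamido on an aromatic carbon. With both values at the limit, the step that the two limits leave unreadable from compound 2 to compound 1 has no readable size. Compound 3 `CC(=O)Nc1ccc(-n2nncc2CN2C(=O)C3(C(C#N)=C(N)Oc4c(N)cc5nc6ccccc6nc5c43)c3ccccc32)cc1` carries the acetamido group of compound 2 on a different core; the difference between the two cores is not broken down here. In this assay compound 3 also gives only the assay limit, > 50000 nM.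

Compound 4 `COc1ccc(-n2nncc2CN2C(=O)C3(C(C#N)=C(N)Oc4c(N)cc5nc6ccccc6nc5c43)c3ccccc32)cc1` has not yet been measured. It stands to compound 3 as compound 1 stands to compound 2: the difference is methoxy in place of acetamido on an aromatic carbon, the same change at the same place. In this assay the step that the limit leaves unreadable from compound 3 to compound 4 is expected to be small or unreadable, because the limit of > 50000 nM in this assay, at which 3 of the 3 values shown sit, places compound 3, together with every other measured value, at the limit. Compound 4 is therefore expected to give about 100000 nM in this assay, most probably reported again as a limit, within a range from 40000 nM to 300000 nM.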

Compound 4, half-maximal inhibitory concentration: > 50000 nM
Compound 4: a limit, no number (the forecaster's own chance of this, stated with the estimate: 85%); the middle value lies beyond the limit too.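

No size can be read for the step between compound 3 and compound 4, or for the one between compound 2 and compound 1, because all of these compounds stop at the same assay limit: the limit of > 50000 nM in this assay, at which 4 of the 4 values shown sit.

The compounds shown leave open whether methoxy in place of acetamido makes any difference in this assay, and how these compounds rank against one another.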